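The compounds below may be only part of what the source reports. "The series", "measured", "known", "first", "only" and "open" are said of these compounds alone.

Four compounds share one core. Compound 1 `Fc1ccc(-c2nnc3nnc(N4CCCC4)n3n2)cc1` carries a fluorophenyl group, compound 3 `O=[N+]([O-])c1ccc(-c2nnc3nnc(N4CCCC4)n3n2)cc1` a nitrophenyl group, compound 2 `CC(C)(C)c1nnc2nnc(N3CCCC3)nn12` a tert-butyl group, and compound 4 `CCc1nnc2nnc(N3CCCC3)nn12` an ethyl group at the same carbon. Among the measured compounds shown here, in a functional assay on BeWo cells (Homo sapiens) for cytotoxicity, read by MTT assay, with a stated time of 72 h (on this read-out lower numbers stand for stronger inhibition and higher numbers for weaker inhibition), compound 2 gives 12500 nM, the only number recorded among the three measured compounds. For compound 1 the result is a limit of the assay, > 100000 nM. For compound 3 the result is likewise a limit, > 100000 nM. For the measured compounds named here, the single step between measured compounds, a step that the two limits leave unreadable from compound 1 to compound 3, cannot be sized because both of its ends rest on (the limit of > 100000 nM in this assay, at which 2 of the 3 values shown sit). The change from compound 2 to compound 4 is ethyl in place of tert-butyl on an aromatic carbon. Going by the values given here, no measured step touches this position with an alkyl group, so nothing measured bears directly on the change; the only firm point is that compound 2 gives a number at all. The step from compound 2 to compound 4 in this assay is therefore expected to be modest, a 2.0-fold higher number from compound 2 to compound 4 (0.30 log units; within the scatter), with its direction uncertain and a real chance that the smaller group drifts toward a limit. Compound 4 is estimated to give 25000 nM, within a range from 8000 nM to 100000 nM.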

Compound 4, half-maximal inhibitory concentration: 5020 nM
Compound 4: the middle estimate sits 5.0-fold (0.70 log units) above what was measured; measured number below the stated range.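

In this assay this position now yields a readable step, a 2.5-fold lower number from compound 2 to compound 4 (0.40 log units; beyond the scatter), with ethyl in place of tert-butyl, and that step lies beyond the usual scatter. Among the compounds shown here, a second alkyl group on this aromatic carbon therefore also gives a number, and of the two, ethyl gives the lower one, so the position responds measurably to a change between alkyl groups, which the single number among the earlier compounds could not show. This remains one pair and not a trend with chain size, and the step between the fluorophenyl and nitrophenyl compounds stays unreadable because both of its ends rest on a limit: the limit of > 100000 nM in this assay, at which 2 of the 4 values shown sit.

The compounds shown leave open whether the number drops further with a methyl group or a plain hydrogen at this carbon, and where a longer chain such as n-butyl or a cyclopropyl group would fall relative to ethyl and tert-butyl. They also leave open whether a benzyl group, which holds its phenyl ring one carbon away from the shared core, would give a number in this assay or would sit at the limit.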